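Rebranching a Side Chain at an Assay Limit

The source may report more compounds than this note shows. Statements on the series, on what has been measured and on what is new or still open speak of the compounds shown alone.

In a physicochemical assay for solubility (on this read-out lower numbers stand for lower solubility and higher numbers for higher solubility), compound 1 `CC(C)CNc1c(C(N)=O)cnn2cc(-c3ccccc3)cc12` gives < 1 ug/mL, which is a limit and not a number. Compound 2 `CC(C)CCNc1c(C(N)=O)cnn2cc(-c3ccccc3)cc12` gives < 1 ug/mL, which is also a limit. For the measured compounds named here, the only measured step is a step that the two limits leave unreadable from compound 1 to compound 2, so it offers no size to build on. What the data show is the limit of < 1 ug/mL in this assay, at which 2 of the 2 values shown sit. Compound 3 `CC(C)(C)CNc1c(C(N)=O)cnn2cc(-c3ccccc3)cc12` rearranges the side chain of compound 2: tert-butyl in place of isobutyl on a saturated chain carbon bound to a nitrogen on an aromatic ring. Nothing here points to a change beyond the scatter, in either direction. The estimated step is a step that the limit leaves unreadable from compound 2 to compound 3. For compound 3 the expected value is 0.6 ug/mL, within an estimated range of 0.2 ug/mL to 1.5 ug/mL.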

Compound 3, solubility: < 1 ug/mL
Compound 3 gave a limit, no number; the forecaster's own chance of this, stated with the estimate: 85%; the middle value lies beyond the limit too.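

No new step can be read for compound 3, because compound 1, compound 2 and compound 3 all give limits rather than numbers: the limit of < 1 ug/mL in this assay, at which 3 of the 3 values shown sit. Going by these compounds, whether these three side chains truly differ in this assay remains open.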